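The compounds below may be only part of what the source reports. "The series", "measured", "known", "first", "only" and "open" are said of these compounds alone.

Compound 1 `O=S(=O)(/C=C/c1ccccn1)c1ccccc1F`: 1050 nM
Compound 2 `O=S(=O)(/C=C/c1cccc(Cl)n1)c1ccccc1F`: 898 nM
Compound 3 `O=S(=O)(/C=C/c1cccnc1)c1ccccc1F`: 6860 nM

These three compounds were measured in an assay on U2OS cells for activation of nuclear factor erythroid 2-related factor 2 (Homo sapiens), read by beta-arrestin recruitment, with a stated time of 6 h; on this read-out lower numbers stand for an effect already at smaller amounts and higher numbers for an effect only at larger amounts of compound. Compound 2 differs from compound 1 by chloro in place of hydrogen on an aromatic carbon, and this gave a 1.2-fold lower number from compound 1 to compound 2 (0.07 log units; within the scatter). Compound 3 differs from compound 1 in its core, (pyridin-3-yl in place of pyridin-2-yl on a double-bonded chain carbon bound to a double-bonded chain carbon), which gave a 6.5-fold higher number from compound 1 to compound 3 (0.82 log units; beyond the scatter). Compound 4 `O=S(=O)(/C=C/c1ccc(Cl)nc1)c1ccccc1F` has not yet been measured; it differs from compound 3 by chloro in place of hydrogen on an aromatic carbon. Going by the values given here, this is the same kind of change as the one from compound 1 to compound 2, though not the same: there the place is meta to a large group, here it is para to a large group. Because the earlier step was a 1.2-fold lower number from compound 1 to compound 2 (0.07 log units; within the scatter), only a small step is expected here as well, a 1.2-fold lower number from compound 3 to compound 4 (0.10 log units; within the scatter). Compound 4 is therefore estimated at 5500 nM, most likely falling between 2500 nM and 12000 nM.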

Compound 4, half-maximal effective concentration: 2550 nM
The estimate for compound 4 lay 2.2-fold (0.33 log units) above the measured number; the range from low to high includes it.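

In this assay, chloro in place of hydrogen gave a 2.7-fold lower number from compound 3 to compound 4 (0.43 log units; beyond the scatter). Set beside the earlier step on the other core, this result differs by no more than two such steps would be expected to by chance: the same change on two cores in this assay, a 1.2-fold lower number (0.07 log units; within the scatter) from compound 1 to compound 2 and a 2.7-fold lower number (0.43 log units; beyond the scatter) from compound 3 to compound 4, 2.3-fold (0.36 log units) apart, within the scatter of two such steps. The change therefore carried across these two cores without a clear difference in its effect, but two pairs do not make a rule, and because the chloro sits at a different place on each core, they cannot separate the effect of the core from that of the place.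

The compounds shown leave open whether a methoxy group or an amine in place of the chloro would give a similar step. They also leave open whether the chloro step would hold on any further core.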